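Para-substituted aryl carbamate selenocyanates: a chloro analogue

A few compounds are considered here, and "the series" means these few. Any claim that something is new, unique, unknown or untested is made for them only; others in the source may bear on it.

Compound 2 `Cc1ccc(OC(=O)Nc2ccc([Se]C#N)cc2)cc1`: 44200 nM
Compound 1 `N#C[Se]c1ccc(NC(=O)Oc2ccc(F)cc2)cc1`: 48400 nM

In a functional assay on HTB-54 cells (Homo sapiens) for cytotoxicity, read by MTT assay, with a stated time of 72 h (a higher number here means a weaker inhibitor of growth, a lower number a stronger inhibitor of growth), compound 2 gives 44200 nM, the lowest of the two numbers shown, with compound 1 nearest at 48400 nM; the two lie within the scatter of each other. Compound 3 `N#C[Se]c1ccc(NC(=O)Oc2ccc(Cl)cc2)cc1` is not yet measured. It differs from compound 2 by chloro in place of methyl on an aromatic carbon. Among the compounds with values here, only one measured step bears on it: a 1.1-fold lower number from compound 1 to compound 2 (0.04 log units; within the scatter), a swap at the same aromatic carbon that left the number essentially unchanged. The change to compound 3 is a second swap at that carbon, so no step beyond the scatter is expected in this assay, and the estimated step is a 1.1-fold lower number from compound 2 to compound 3 (0.04 log units; within the scatter). For compound 3 the expected value is 40000 nM, with a range of 20000 nM to 80000 nM.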

Compound 3, concentration for total growth inhibition: 41400 nM
For compound 3 the middle estimate is 1.0-fold (0.01 log units) below the measured one; the measured number falls inside the stated range.
By their numbers in this assay, from the lowest: compounds 3, 2 and 1 (each within the scatter of the next).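

With chloro, three different groups have now been read at this aromatic carbon, para to a large group, and none separates from the others in this assay: the step from methyl (a 1.1-fold lower number from compound 2 to compound 3 (0.03 log units; within the scatter)) and the step from fluoro (a 1.2-fold lower number from compound 1 to compound 3 (0.07 log units; within the scatter)) both lie within the scatter. The earlier pair offered a single swap, whereas compound 3 adds two more, so the flat reading at this carbon now rests on three compounds rather than two. Nothing available here accounts for this flat reading.

The compounds shown leave open whether an amine, a carboxylic acid or a longer chain at this carbon would give a number beyond the scatter of these three. Also open, from the compounds shown here alone, is what a change elsewhere in the shared core, such as replacing the selenocyanate, would do to the number.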